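The source may report more compounds than this note shows. Statements on the series, on what has been measured and on what is new or still open speak of the compounds shown alone.

Three compounds share one core and differ only in the aromatic group hanging from its double bond. Among the compounds with values here, in a functional assay on HCT-116 cells (Homo sapiens) for cytotoxicity, read by MTT assay, with a stated time of 72 h (a lower number here means a stronger inhibitor, a higher number a weaker inhibitor), compound 2 `Cc1ccc(/C=C2\S/C(=N\c3csc(-c4ccc(Cl)cc4)c3)NC2=O)cc1` gives 1000 nM, the low end of the numbers so far. Compound 1 `COc1ccc(/C=C2\S/C(=N\c3csc(-c4ccc(Cl)cc4)c3)NC2=O)cc1` gives 1300 nM, and a 1.3-fold lower number from compound 1 to compound 2 (0.11 log units; within the scatter) lies within the scatter, so the two cannot be told apart. Compound 3 `O=C1N/C(=N/c2csc(-c3ccc(Cl)cc3)c2)S/C1=C\c1ccc2ccccc2c1` gives 3000 nM, with a 3.0-fold higher number from compound 2 to compound 3 (0.48 log units; beyond the scatter) and a 2.3-fold higher number from compound 1 to compound 3 (0.36 log units; beyond the scatter), both modest but beyond the scatter. Compound 4 `COc1ccc(/C=C2\S/C(=N\c3csc(-c4ccc(Cl)cc4)c3)NC2=O)cc1OC` differs from compound 2 by 3,4-dimethoxyphenyl in place of 4-methylphenyl on a double-bonded chain carbon bound to a double-bonded ring carbon. Swapping methyl for methoxy changed little, while the bulkier naphthalen-2-yl raised the number; a second methoxy group is therefore expected to give only a small rise, a 1.5-fold higher number from compound 2 to compound 4 (0.18 log units; within the scatter). Compound 4 is estimated at 1500 nM, likely between 600 nM and 3800 nM.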

Compound 4, half-maximal inhibitory concentration: 1700 nM
For compound 4 the middle estimate is 1.1-fold (0.05 log units) below the measured one, and the stated range covers the measured number.
By their numbers in this assay, from the lowest: compounds 2, 1, 4 and 3 (each within the scatter of the next, the first and the last beyond it).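

A second methoxy group on this aromatic ring does not separate the compounds, with a 1.3-fold higher number from compound 1 to compound 4 (0.12 log units; within the scatter) and a 1.7-fold higher number from compound 2 to compound 4 (0.23 log units; within the scatter) both within the scatter. The 3,4-dimethoxyphenyl group, with more heavy atoms than 4-methylphenyl, is therefore accepted at this position, and a 1.8-fold lower number from compound 3 to compound 4 (0.25 log units; within the scatter) also stays within the scatter, so compound 4 cannot be told apart from any of the others. No available evidence explains this result. Still open, going by these compounds, is how an amine or a carboxylic acid on this aromatic ring would fare in this assay in place of methoxy.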